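Moving the fluorine on the pendant phenyl ring

The source may hold more compounds than are shown below. What is called first, only, known or untested is meant among the compounds shown, and "the series" means these compounds.

Measured compounds:
compound 1 `c1ccc(-c2cn3ccnc3c(-c3ccc4ncn(C5CCCCC5)c4c3)n2)cc1`, 29.3%
compound 2 `c1ccc2c(-c3cn4ccnc4c(-c4ccc5ncn(C6CCCCC6)c5c4)n3)cccc2c1`, 5.1%
compound 3 `Fc1ccc(-c2cn3ccnc3c(-c3ccc4ncn(C5CCCCC5)c4c3)n2)cc1`, 1.17%

In a functional assay on DU-145 cells (Homo sapiens) for inhibition, read by sulforhodamine B assay, with a stated time of 48 h, tested at 10 uM (a higher number here means more inhibition at the concentration tested (going by the name of the read-out), a lower number less inhibition), compound 3 gives 1.17%, the lowest of the three numbers; compound 2 sits within the scatter of it, while compound 1 lies well above, as a number 28.1 percentage points lower from compound 1 to compound 3 (beyond the scatter) shows. Compound 4 `Fc1ccccc1-c1cn2ccnc2c(-c2ccc3ncn(C4CCCCC4)c3c2)n1` differs from compound 3 by 2-fluorophenyl in place of 4-fluorophenyl on an aromatic carbon. Among the compounds with values here, no measured step moves a fluorine around the same ring; the only steps at this position are a number 28.1 percentage points lower from compound 1 to compound 3 (beyond the scatter) and a number 3.9 percentage points lower from compound 2 to compound 3 (within the scatter), and both lead to low numbers once the fluorine is present. Because compound 3 gives 1.17%, which is already near the bottom, compound 4 is expected to show a number 6.8 percentage points higher from compound 3 to compound 4 (within the scatter), no change beyond the scatter. Compound 4 is therefore estimated at 8%, within 0% to 22%.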

Compound 4, a percentage reported as inhibition, at one concentration (the size of the read-out at that concentration, not a potency): 0.96%
Estimate against measurement, compound 4: 7 percentage points above; low and high end bracket the measured number.
By their numbers in this assay, from the lowest: compounds 4, 3 and 2 (each within the scatter of the next); then compound 1.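

In this assay, the place of the fluorine on this ring does not separate the two isomers, with a number 0.2 percentage points lower from compound 3 to compound 4 (within the scatter). The 2-fluorophenyl group also stays within the scatter of the naphthalen-1-yl analogue, with a number 4.1 percentage points lower from compound 2 to compound 4 (within the scatter). Against the unsubstituted phenyl, however, fluoro in place of hydrogen again gives a drop beyond the scatter, with a number 28.3 percentage points lower from compound 1 to compound 4 (beyond the scatter), so both fluorine placements shown go with low numbers. From the compounds shown here alone, whether an amine or a carboxylic acid on this phenyl ring would give a number nearer that of compound 1 stays open. No measurement here accounts for the low numbers of the fluorinated compounds.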